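The compounds below may be only part of what the source reports. "The series", "measured", "known", "first", "only" and "open" are said of these compounds alone.

Three compounds have been measured in a functional assay on A549 cells (Homo sapiens) for antiproliferative activity, read by MTT assay, with a stated time of 48 h; a higher number here means a weaker inhibitor, a lower number a stronger inhibitor:

Compound 1 `CCOc1cc(-c2ccc3[nH]ccc3c2)cn2c(-c3cc(OC)c(OC)c(OC)c3)nnc12` gives 589 nM.
Compound 2 `COc1cc(-c2nnc3c(OC(C)C)cc(-c4ccc5[nH]ccc5c4)cn23)cc(OC)c1OC` gives 1250 nM.
Compound 3 `CCOc1cc(-c2ccc3c(ccn3C)c2)cn2c(-c3cc(OC)c(OC)c(OC)c3)nnc12` gives 334 nM.

Compounds 1 and 2 share the same core and differ in one place only: hydrogen in place of methyl on a saturated chain carbon bound to an oxygen on an aromatic ring and a saturated chain carbon. That change gave a 2.1-fold lower number from compound 2 to compound 1 (0.33 log units; beyond the scatter). Compounds 1 and 3 also differ in one place, methyl in place of hydrogen on an aromatic nitrogen, and the step of a 1.8-fold lower number from compound 1 to compound 3 (0.25 log units; within the scatter) is too small to be read as a real difference. Between compounds 2 and 3 the difference between the two cores is not broken down here.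

Compound 4 `COc1cc(-c2nnc3c(OC)cc(-c4ccc5c(ccn5C)c4)cn23)cc(OC)c1OC` has not been measured. It differs from compound 3 as follows: hydrogen in place of methyl on a saturated chain carbon bound to an oxygen on an aromatic ring. Within the data shown here, this is the same kind of change as the one from compound 2 to compound 1, but not the same: there the saturated chain carbon was bound to an oxygen on an aromatic ring and a saturated chain carbon, here it is bound to an oxygen on an aromatic ring only. Because the earlier trimming of the chain gave a 2.1-fold lower number from compound 2 to compound 1 (0.33 log units; beyond the scatter), the step from compound 3 to compound 4 in this assay is expected to be of similar direction but modest in size, a 1.5-fold lower number from compound 3 to compound 4 (0.18 log units; within the scatter), and it may fall within the scatter. On that basis compound 4 is estimated to give 220 nM, with a likely range from 90 nM to 550 nM.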

Compound 4, half-maximal inhibitory concentration: 69 nM
Estimate against measurement, compound 4: 3.2-fold (0.50 log units) above, outside the stated range (below it).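

In this assay, replacing ethoxy with methoxy gave a 4.8-fold lower number from compound 3 to compound 4 (0.68 log units; beyond the scatter), so removing one methyl from the end of the chain lowered the number here, just as trimming the chain did on the core of compound 1. The two steps point the same way, and their sizes cannot be told apart: the same change on two cores in this assay, a 2.1-fold lower number (0.33 log units; beyond the scatter) from compound 2 to compound 1 and a 4.8-fold lower number (0.68 log units; beyond the scatter) from compound 3 to compound 4, 2.3-fold (0.36 log units) apart, within the scatter of two such steps. On these two cores, then, the change carried over in direction, but the larger new step should not be read as a stronger effect on the core of compound 3, and two pairs cannot show that the step has a fixed size or that it would hold on other cores in this series.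

From the compounds shown here alone, it remains open what happens when the chain on this oxygen is replaced altogether, for example when a hydroxyl group takes the place of the methoxy group or an amine is attached at the end of a longer chain. Going by these compounds, it is also open how this position would respond to a cyclopropyl group, and whether an ethyl group on the aromatic nitrogen would behave like the methyl group of compound 3.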